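A few compounds are considered here, and "the series" means these few. Any claim that something is new, unique, unknown or untested is made for them only; others in the source may bear on it.

Compound 1 `CCCCCCCCCCc1ccc(-c2noc(CCCNC)n2)cc1`: 45%
Compound 2 `CCCCCCCCCCc1ccc(-c2noc([C@H]3CCCN3)n2)cc1`: 12%
Compound 3 `CCCCCCCCCCc1ccc(-c2noc([C@H]3CCC[C@@H](N)C3)n2)cc1`: 29%

All three have been measured in an assay on HeLa cells for inhibition of sphingosine-1-phosphate transporter SPNS2 (Mus musculus), read by LC-MS, tested at 2 uM; a lower number here means less inhibition, a higher number more inhibition at the concentration tested (going by the name of the read-out). On these numbers compound 2 stands lowest of the three: compound 3 is the nearer neighbour and compound 1 the furthest, and both gaps are beyond the scatter. The unmeasured compound 4 `CCCCCCCCCCc1ccc(-c2noc(CC(O)CN)n2)cc1` differs from compound 2 in one place: 3-amino-2-hydroxypropyl in place of pyrrolidin-2-yl on an aromatic carbon.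

Within the data shown here, two measured steps bear on this change. The step of a number 33 percentage points lower from compound 1 to compound 2 (beyond the scatter) shows a large fall when 3-(methylamino)propyl is exchanged for pyrrolidin-2-yl on the aromatic carbon; the step of a number 17 percentage points higher from compound 2 to compound 3 (beyond the scatter) shows a modest rise when pyrrolidin-2-yl gives way to 3-aminocyclohexyl. Compound 4 returns to an open chain on that carbon, as in compound 1, though with a different chain, so a rise beyond the scatter is expected, of a size between these two steps, a number 23 percentage points higher from compound 2 to compound 4 (beyond the scatter). For compound 4 the expected value is 35%, estimated to lie between 15% and 55%.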

Compound 4, a percentage reported as inhibition, at one concentration (the size of the read-out at that concentration, not a potency): 59%
Compound 4: the middle estimate sits 24 percentage points below what was measured; the measured number lies above the stated range.
By their numbers in this assay, from the lowest: compound 2; then compound 3; then compound 1; then compound 4.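

In this assay, among these compounds, the ring-free 3-amino-2-hydroxypropyl on this aromatic carbon gives the largest step seen at this position so far (a number 47 percentage points higher from compound 2 to compound 4 (beyond the scatter)), and it also clearly exceeds the cyclic 3-aminocyclohexyl (a number 30 percentage points higher from compound 3 to compound 4 (beyond the scatter)). The earlier compounds shown here showed only falls on moving away from the open chain of compound 1, whereas 2-amino-1-hydroxyethyl in place of 2-(methylamino)ethyl on the saturated chain carbon bound to the aromatic carbon now shows a gain (a number 14 percentage points higher from compound 1 to compound 4 (beyond the scatter)). The open chain can therefore itself be altered with a rise, and compound 4 stands beyond the scatter of all three others.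

That last step combines a new hydroxy group with a change from methylamino to amino, and a plain 3-aminopropyl chain would be needed to separate the two. Nothing available here explains the gain.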